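Methyl groups added to the hydroxyphenyl of compound 3

A few compounds are considered here, and "the series" means these few. Any claim that something is new, unique, unknown or untested is made for them only; others in the source may bear on it.

Three measured compounds share one core and differ only in the aryl group on a carbon with a double bond to nitrogen. In a functional assay on NCI-H460 cells (Homo sapiens) for cytotoxicity, read by MTT assay, with a stated time of 72 h (a higher number here means a weaker inhibitor, a lower number a stronger inhibitor), compound 1 `CN(C)CCn1cnnc1-c1cc(Oc2ccc(NC(=O)N/N=C/c3ccccc3O[N+](=O)[O-])cc2F)ccn1` gives 1270 nM, compound 2 `CN(C)CCn1cnnc1-c1cc(Oc2ccc(NC(=O)N/N=C/c3ccc(F)cc3F)cc2F)ccn1` gives 1930 nM, and compound 3 `CN(C)CCn1cnnc1-c1cc(Oc2ccc(NC(=O)N/N=C/c3ccc(O)cc3)cc2F)ccn1` gives 1780 nM. Compound 3 sits between the other two, and every step among them stays within the scatter: a 1.5-fold higher number from compound 1 to compound 2 (0.18 log units; within the scatter), a 1.4-fold higher number from compound 1 to compound 3 (0.15 log units; within the scatter) and a 1.1-fold lower number from compound 2 to compound 3 (0.04 log units; within the scatter). Compound 4 `Cc1cc(/C=N/NC(=O)Nc2ccc(Oc3ccnc(-c4nncn4CCN(C)C)c3)c(F)c2)cc(C)c1O` carries the change (4-hydroxy-3,5-dimethylphenyl in place of 4-hydroxyphenyl on a carbon with a double bond to nitrogen). All three measured steps bear on it, since each swapped the aryl group at that same carbon, and none moved the number beyond the scatter. A step of comparable size is therefore expected in this assay for compound 4, with no clear direction, and compound 4 is estimated at 1700 nM, with a range from 800 nM to 3600 nM, which corresponds to an expected step of a 1.0-fold lower number from compound 3 to compound 4 (0.02 log units; within the scatter).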

Compound 4, half-maximal inhibitory concentration: 2010 nM
Estimate against measurement, compound 4: 1.2-fold (0.07 log units) below; low and high end bracket the measured number.
By their numbers in this assay, from the lowest: compounds 1, 3, 2 and 4 (each within the scatter of the next).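

In this assay the added methyl groups of the 4-hydroxy-3,5-dimethylphenyl group leave the number within the scatter, with a 1.1-fold higher number from compound 3 to compound 4 (0.05 log units; within the scatter) as the step from the plain 4-hydroxyphenyl group. Compound 4 is likewise not separated from the other two aryl variants, with a 1.0-fold higher number from compound 2 to compound 4 (0.02 log units; within the scatter) on one side and a 1.6-fold higher number from compound 1 to compound 4 (0.20 log units; within the scatter) on the other, so all four aryl groups on the carbon with a double bond to nitrogen now lie within the scatter of one another, and this holds with methyl groups present on the ring. Nothing available bears on why this position responds so little.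

The compounds shown leave open whether an amine, a carboxylic acid or a longer chain on this aryl ring would move the number beyond the scatter. They also leave open what a plain phenyl group at this carbon would give.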